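This account rests on a few compounds, and the source may have more. Where it says the series, first, only, none or still open, it means among the compounds named here.

In an assay for inhibition of serine/threonine-protein kinase PLK2 (Homo sapiens), read by FRET and Z'-LYTE, with a stated time of 1 h (a higher number here means a weaker inhibitor, a lower number a stronger inhibitor), compound 1 `CCC1C(=O)N(C)c2cnc(-n3ccc4cc(C(=O)NC)ccc43)nc2N1c1ccn(C)n1` gives 218 nM, and compound 2 `CC[C@@H]1C(=O)N(C)c2cnc(-n3ccc4ccccc43)nc2N1C1CCCC1` gives 355 nM, the higher of the two numbers, although its gap to compound 1 lies within the scatter. Compound 3 `CC[C@@H]1C(=O)N(C)c2cnc(-n3ccc4cc(C(=O)NC5CCCC5)ccc43)nc2N1C1CCCC1` differs from compound 2 by cyclopentylcarbamoyl in place of hydrogen on an aromatic carbon. Among the compounds with values here, no measured pair isolates this change; compound 1 also carries a carbamoyl group on its core and its number sits close to that of compound 2. The step of a 1.6-fold lower number from compound 2 to compound 3 (0.21 log units; within the scatter) is therefore expected to be small, leaning if anything toward a lower number, and probably not beyond the scatter. Compound 3 is estimated at 220 nM, within 70 nM to 650 nM.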

Compound 3, half-maximal inhibitory concentration: 7.06 nM
Compound 3: the middle estimate sits 31-fold (1.49 log units) above what was measured; measured number outside the range, below it.
By their numbers in this assay, from the lowest: compound 3; then compounds 1 and 2 (each within the scatter of the next).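

In this assay, cyclopentylcarbamoyl in place of hydrogen on this aromatic carbon gives a 50-fold lower number from compound 2 to compound 3 (1.70 log units; beyond the scatter), a large step well beyond the scatter. This shows that the number responds strongly to substitution at this position, which carries only hydrogen in compound 2. No measurement shown explains the size of this step. On these data alone, whether the carbamoyl part or the cyclopentyl ring carries the step stays open. Also open, as far as these compounds go, is how an unsubstituted carboxamide or a carboxylic acid on this carbon would read, with the rest of compound 3 unchanged.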